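The source may report more compounds than this note shows. Statements on the series, on what has been measured and on what is new or still open speak of the compounds shown alone.

Working notes on the series. For the measured compounds named here, in a functional assay on HL-60 cells (Homo sapiens) for antiproliferative activity, read by XTT assay, with a stated time of 72 h (on this read-out higher numbers stand for weaker inhibition and lower numbers for stronger inhibition), compound 3 `COc1ncnc2c1c(I)cn2[C@@H]1O[C@H](CO)[C@@H](O)[C@H]1O` gives 2300 nM and is the only compound with a number in this set. Compound 1 `Nc1nc(N)c2c(-c3ccsc3)cn([C@@H]3O[C@H](CO)[C@@H](O)[C@H]3O)c2n1` reaches only the limit of this assay, > 20000 nM. Compound 2 `COc1nc(N)nc2c1c(-c1cc3ccccc3o1)cn2[C@@H]1O[C@H](CO)[C@@H](O)[C@H]1O` likewise sits at the limit, > 20000 nM. Going by the values given here, this leaves the field thin: the limit of > 20000 nM in this assay, at which 2 of the 3 values shown sit, so no step between measured compounds can be drawn.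

The next compound, compound 4 `C#Cc1cn([C@@H]2O[C@H](CO)[C@@H](O)[C@H]2O)c2ncnc(OC)c12`, differs from compound 3 by ethynyl in place of iodo on an aromatic carbon. Among the compounds with values here, no measured pair shows this kind of exchange, so the expected step from compound 3 to compound 4 is taken as small, a 1.5-fold lower number from compound 3 to compound 4 (0.19 log units; within the scatter), with no direction claimed beyond the scatter. Compound 4 is accordingly estimated at 1500 nM in this assay, within 400 nM to 6000 nM.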

Compound 4, half-maximal inhibitory concentration: 190 nM
Compound 4: the middle estimate sits 7.9-fold (0.90 log units) above what was measured, and the stated range ends above it.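

In this assay, for the compounds shown here, the aromatic carbon two ring bonds from the ring nitrogen proves sensitive to the group it carries: ethynyl in place of iodo gives a 12-fold lower number from compound 3 to compound 4 (1.08 log units; beyond the scatter) and is the first step that can be read. The earlier compounds shown here offered no such reading, since none of them differed in one place only. Nothing at hand gives a cause for this step.

Going by these compounds, whether a longer alkyne such as propynyl, a nitrile or an amine at this carbon would keep this gain stays open. So does the effect of the methoxy group on the shared core, which no single change here isolates.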